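Nitro in place of methoxy on the propoxy compounds

The compounds below may be only part of what the source reports. "The series", "measured", "known", "first", "only" and "open" are said of these compounds alone.

Measured in a functional assay on the whole organism with Rattus norvegicus as the target; a higher number here means that more compound is needed for the effect, a lower number that less compound is needed:
compound 1 `CCOc1ccccc1-c1ncc(-c2nn[nH]n2)c(O)n1`: 0.09 mg/kg
compound 2 `CCCOc1ccccc1-c1ncc(-c2nn[nH]n2)c(O)n1`: 0.04 mg/kg
compound 3 `CCCOc1ccc(OC)cc1-c1ncc(-c2nn[nH]n2)c(O)n1`: 0.03 mg/kg

In this assay compound 3 (0.03 mg/kg) and compound 2 (0.04 mg/kg) lie within the scatter of each other, and both numbers are lower than that of compound 1 (0.09 mg/kg).

Next is compound 4 `CCCOc1ccc([N+](=O)[O-])cc1-c1ncc(-c2nn[nH]n2)c(O)n1`, which has nitro in place of methoxy on an aromatic carbon, para to a propoxy group (nitro in place of methoxy on an aromatic carbon). For the measured compounds named here, two measured steps bear on it. Adding methoxy at this same carbon gave only a small change (a 1.3-fold lower number from compound 2 to compound 3 (0.12 log units; within the scatter)). Lengthening the chain gave a modest one (a 2.3-fold lower number from compound 1 to compound 2 (0.35 log units; beyond the scatter)), but at a different place. Going by the values given here, no nitro compound has been measured, so the evidence is indirect and the range stays wide. No step beyond the scatter is expected, and the estimated step is small (a 1.3-fold higher number from compound 3 to compound 4 (0.12 log units; within the scatter)). For compound 4 the expected value in this assay is 0.04 mg/kg (estimated range 0.015 mg/kg to 0.12 mg/kg).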

Compound 4, dose for 50% inhibition: 5 mg/kg
Compound 4: middle estimate off by 130-fold (2.10 log units), on the low side, outside the stated range (above it).
By their numbers in this assay, from the lowest: compounds 3 and 2 (each within the scatter of the next); then compound 1; then compound 4.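

The carbon para to a propoxy group is not indifferent to its substituent. In this assay, nitro in place of methoxy gives a 170-fold higher number from compound 3 to compound 4 (2.22 log units; beyond the scatter), and nitro in place of hydrogen gives a 130-fold higher number from compound 2 to compound 4 (2.10 log units; beyond the scatter), whereas methoxy in place of hydrogen at this carbon gave only a 1.3-fold lower number from compound 2 to compound 3 (0.12 log units; within the scatter), so tolerance of methoxy here did not extend to nitro. Nothing shown accounts for the difference between these two groups.

From the compounds shown here alone, it remains open whether the loss is particular to nitro or extends to other groups at this carbon, such as an amine, a nitrile, a chlorine or a carboxylic acid. Also open, going by these compounds, is whether nitro has a similar effect with the shorter chain of compound 1 or with a chain longer than propoxy.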